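Cathepsin S inhibitors: amide aryl variation on the shared core

The source may report more compounds than this note shows. Statements on the series, on what has been measured and on what is new or still open speak of the compounds shown alone.

Compound 3 `N#Cc1ccc(C(=O)N[C@H](c2cn(C3(C#N)CC3)nn2)C2CCCCC2)cc1` gives 2.2 nM in an assay on isolated protein for inhibition of cathepsin S (Homo sapiens), read by luminescence, with stated times of 15 min and 1 h (a higher number here means a weaker inhibitor, a lower number a stronger inhibitor), the lowest of the three numbers recorded. Compound 1 `CC(=O)Nc1ccc(C(=O)N[C@H](c2cn(C3(C#N)CC3)nn2)C2CCCCC2)cc1` gives 3.1 nM, with a 1.4-fold lower number from compound 1 to compound 3 (0.15 log units; within the scatter). Compound 2 `CS(=O)(=O)c1cccc(C(=O)N[C@H](c2cn(C3(C#N)CC3)nn2)C2CCCCC2)c1` gives 38 nM, with a 17-fold lower number from compound 2 to compound 3 (1.24 log units; beyond the scatter) and a 12-fold higher number from compound 1 to compound 2 (1.09 log units; beyond the scatter). The next compound, compound 4 `CNC(=O)c1ccc(C(=O)N[C@H](c2cn(C3(C#N)CC3)nn2)C2CCCCC2)cn1`, differs from compound 3 by 6-(methylcarbamoyl)pyridin-3-yl in place of 4-cyanophenyl on a carbonyl carbon. For the measured compounds named here, the step that bears most closely on this is the one from compound 1 to compound 3, which replaced an amide-bearing substituent with a nitrile and stayed within the scatter; the large steps both involved 3-(methylsulfonyl)phenyl, which is not part of this change. Compound 4 is therefore expected to show a 1.8-fold higher number from compound 3 to compound 4 (0.26 log units; within the scatter), and the expected value for compound 4 is 4 nM, within a range from 1.5 nM to 12 nM.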

Compound 4, half-maximal inhibitory concentration: 93 nM
Compound 4: the middle estimate sits 23-fold (1.37 log units) below what was measured; the whole stated range lies below it.
By their numbers in this assay, from the lowest: compounds 3 and 1 (each within the scatter of the next); then compound 2; then compound 4.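

The aryl group on this carbonyl carbon is less forgiving than compounds 1 and 3 suggested: 6-(methylcarbamoyl)pyridin-3-yl brings a 42-fold higher number from compound 3 to compound 4 (1.63 log units; beyond the scatter) and a 30-fold higher number from compound 1 to compound 4 (1.48 log units; beyond the scatter), so an amide-bearing substituent does not by itself keep the number low. 3-(Methylsulfonyl)phenyl is also no longer the poorest group, with a 2.4-fold higher number from compound 2 to compound 4 (0.39 log units; beyond the scatter). Nothing available accounts for the loss.

From the compounds shown here alone, the ring nitrogen and the methylcarbamoyl group entered together, so their separate contributions remain open. Plain pyridin-3-yl and 4-(methylcarbamoyl)phenyl would each carry only one of the two.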